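Fluoro for methyl on the aryl ether ring

A few compounds are considered here, and "the series" means these few. Any claim that something is new, unique, unknown or untested is made for them only; others in the source may bear on it.

Compound 1 `Cc1ccccc1COc1ccc(-c2cc(CN3CCN(Cc4ccc(C(F)(F)F)cc4)CC3)no2)cc1`: 1200 nM
Compound 2 `Fc1ccccc1COc1ccc(-c2cc(CN3CCN(Cc4ccc(C(F)(F)F)cc4)CC3)no2)cc1`: 1500 nM
Compound 3 `Cc1cc(OCc2cccc(C#N)c2)ccc1-c1cc(CN2CCN(Cc3ccc(C(F)(F)F)cc3)CC2)no1`: 1500 nM

Of the compounds shown here, three have been measured in a functional assay on Huh-7 cells (Homo sapiens) for antiproliferative activity, read by sulforhodamine B assay, with a stated time of 72 h; a higher number here means a weaker inhibitor, a lower number a stronger inhibitor. The difference between the core of compound 1 and the core of compound 3 is not broken down here. Compound 2 differs from compound 1 by fluoro in place of methyl on an aromatic carbon, and in this assay that step amounts to a 1.3-fold higher number from compound 1 to compound 2 (0.10 log units; within the scatter). Compound 3 and compound 2 give the same number at the digits shown, and compound 3 and compound 1 lie within the scatter of each other.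

Compound 4 `N#Cc1cccc(COc2ccc(-c3cc(CN4CCN(Cc5ccc(C(F)(F)F)cc5)CC4)no3)c(F)c2)c1` is not yet measured. It differs from compound 3 by fluoro in place of methyl on an aromatic carbon. This is the same kind of change as that from compound 1 to compound 2, but the place is not identical: here the aromatic carbon is also meta to a (3-cyanobenzyl)oxy group. Resting on the step observed from compound 1 to compound 2, compound 4 is expected to show a 1.2-fold higher number from compound 3 to compound 4 (0.08 log units; within the scatter) in this assay. Compound 4 is therefore estimated at 1800 nM, with a likely range of 900 nM to 3600 nM.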

Compound 4, half-maximal inhibitory concentration: 400 nM
The estimate for compound 4 lay 4.5-fold (0.65 log units) above the measured number; measured number below the stated range.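

In this assay, fluoro in place of methyl on an aromatic carbon gives a 3.8-fold lower number from compound 3 to compound 4 (0.57 log units; beyond the scatter). The step therefore does not carry over at one size between these two cores: the same change on two cores in this assay, a 1.3-fold higher number (0.10 log units; within the scatter) from compound 1 to compound 2 and a 3.8-fold lower number (0.57 log units; beyond the scatter) from compound 3 to compound 4, 4.7-fold (0.67 log units) apart, beyond the scatter of two such steps

Two pairs cannot say whether the gap follows from the place of the change or from the rest of each core, and they set no rule for other cores in this series. The compounds shown leave open whether chloro or methoxy on that same aromatic carbon would behave as fluoro does. Also open, from the compounds shown here alone, is whether the fluoro step would hold if an amine or a carboxylic acid replaced the nitrile of compound 4.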